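The source may report more compounds than this note shows. Statements on the series, on what has been measured and on what is new or still open speak of the compounds shown alone.

Measured so far in an ADME assay on MDCK cells (Canis lupus familiaris) for cytotoxicity, read by MTT assay, with a stated time of 24 h; on this read-out lower numbers stand for higher toxicity in this test and higher numbers for lower toxicity in this test:
Compound 1 `Cc1cc(CNS(=O)(=O)c2ccc([N+](=O)[O-])cc2)c(C)o1`: > 152000 nM
Compound 2 `Cc1cc(CNS(=O)(=O)c2ccc([N+](=O)[O-])cc2)c(C)s1`: > 204000 nM

Compound 1 reaches only a limit of the assay, > 152000 nM, and not a number. Compound 2 likewise stands only at a limit, > 204000 nM.

Compound 3 `O=[N+]([O-])c1ccc(S(=O)(=O)NCc2ccsc2)cc1` differs from compound 2 in one place: thiophen-3-yl in place of 2,5-dimethylthiophen-3-yl on a saturated chain carbon bound to a sulfonamide nitrogen. In words, thiophen-3-yl takes the place of 2,5-dimethylthiophen-3-yl on a saturated chain carbon bound to a sulfonamide nitrogen.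

For the measured compounds named here, only one measured step bears on this, a step that the two limits leave unreadable from compound 1 to compound 2. Its size cannot be read, and it is a different exchange, so it offers only weak guidance. With compound 2 at the limit of > 204000 nM in this assay, at which 1 of the 2 values shown sits, no change beyond the usual scatter is expected in this assay, in either direction. The expected step is a step that the limit leaves unreadable from compound 2 to compound 3. For compound 3 the estimated value is 230000 nM, with an expected range from 100000 nM to 450000 nM.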

Compound 3, half-maximal cytotoxic concentration: 139000 nM
Beside the measured number, compound 3's estimate is 1.7-fold (0.22 log units) above it; the range from low to high includes it.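

For the compounds shown here, compound 3, with thiophen-3-yl on a saturated chain carbon bound to a sulfonamide nitrogen, gives the first true number of this set in this assay, 139000 nM, and not a limit. Thiophen-3-yl in place of 2,5-dimethylthiophen-3-yl gives an at least 1.4-fold lower number from compound 2 to compound 3 (0.16 log units; that floor lies within the scatter), and thiophen-3-yl in place of 2,5-dimethylfuran-3-yl gives an at least 1.0-fold lower number from compound 1 to compound 3 (0.03 log units; that floor lies within the scatter), so neither exchange shows a change beyond the usual scatter. Compound 2 stands only at a limit of the assay, which is why its step has a floor and no full size: the limit of > 204000 nM in this assay, at which 1 of the 3 values shown sits.

Open, from the compounds shown here alone, is how a furan-3-yl group without its methyl groups would compare with compound 3 at this place. Also open, going by these compounds, is how a phenyl group or a carboxylic acid on this chain carbon would read in this assay.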